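Replacing ethoxymethyl with 3-methyl-1,2,4-oxadiazol-5-yl

This account rests on a few compounds, and the source may have more. Where it says the series, first, only, none or still open, it means among the compounds named here.

Values so far in an ADME assay on the whole organism (Rattus norvegicus, strain Fischer 344) for pharmacokinetics, at a dose of 3 mg/kg by the oral route; a lower number here means less compound in the circulation, a higher number more compound in the circulation at the dose given

- Compound 1 `NC(=O)c1sc2nccc(N3CCC[C@H](COCC(=O)N4CCOCC4)C3)c2c1N` gives 501 nM
- Compound 2 `CCOCCOC[C@H]1CCCN(c2ccnc3sc(C(N)=O)c(N)c23)C1` gives 2120 nM

Compound 2 holds the higher of the two numbers in this assay and is the reference for the next change. Compound 3 `Cc1noc(COC[C@H]2CCCN(c3ccnc4sc(C(N)=O)c(N)c34)C2)n1` differs from it as follows: 3-methyl-1,2,4-oxadiazol-5-yl in place of ethoxymethyl on a saturated chain carbon bound to an oxygen on a saturated carbon on a saturated chain carbon bound to an oxygen on a saturated carbon. Among the compounds with values here, one measured step bears on this place (a 4.2-fold higher number from compound 1 to compound 2 (0.63 log units; beyond the scatter)) and it is modest. In that step the group with a ring, in compound 1, carries the lower number. Within the data shown here, no measured compound holds 3-methyl-1,2,4-oxadiazol-5-yl, so the reading rests on compound 1 alone and is weak. A fall of similar or smaller size is therefore expected, with a result near compound 2 not excluded. The expected step is a 2.1-fold lower number from compound 2 to compound 3 (0.33 log units; beyond the scatter) and it stays an estimate. For compound 3 the estimated value is 1000 nM (expected range 350 nM to 2800 nM).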

Compound 3, maximal plasma concentration: 393 nM
Beside the measured number, compound 3's estimate is 2.5-fold (0.41 log units) above it, within the range that was stated.
By their numbers in this assay, from the lowest: compounds 3 and 1 (each within the scatter of the next); then compound 2.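

In this assay, the step of a 5.4-fold lower number from compound 2 to compound 3 (0.73 log units; beyond the scatter) shows that the lower number at this position is not confined to the (morpholin-4-yl)carbonyl of compound 1: a second ring-bearing group, 3-methyl-1,2,4-oxadiazol-5-yl, goes with it too. The step of a 1.3-fold lower number from compound 1 to compound 3 (0.11 log units; within the scatter) leaves these two ring-bearing groups not told apart, so among the three compounds only the ethoxymethyl of compound 2 goes with the high number, and none goes against this. No measurement shown here speaks to the reason for this pattern.

As far as these compounds go, it remains open whether the ring itself or its hetero atoms go with the lower number, and a phenyl or cyclopentyl group in this place would separate the two readings. From the compounds shown here alone, whether a longer ether chain holds the number of compound 2 also stays open.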